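Side-chain amine extension on the shared core

This account rests on a few compounds, and the source may have more. Where it says the series, first, only, none or still open, it means among the compounds named here.

Measured so far:
compound 1 `CC[C@H](NC)C(=O)N[C@@H]1C(=O)N2[C@@H](CC[C@@H]1CN)CC[C@H]2C(=O)NC(c1ccccc1)c1ccccc1`, 51800 nM
compound 2 `CC[C@H](N)C(=O)N[C@@H]1C(=O)N2[C@@H](CC[C@@H]1CCNC(=O)NCc1ccccc1)CC[C@H]2C(=O)NC(c1ccccc1)c1ccccc1`, 83300 nM

Both compounds were run in a functional assay on HL-60 cells (Homo sapiens) for cytotoxicity, read by MTT assay, with a stated time of 96 h; a lower number here means a stronger inhibitor, a higher number a weaker inhibitor. Compound 1 gives 51800 nM and compound 2 gives 83300 nM; compound 1 carries the lower of the two numbers, but the gap to compound 2 is within the scatter, so the two read as equivalent on the data so far. Both numbers lie high on the concentration scale.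

The next compound is compound 3 `CCNCC[C@H]1CC[C@H]2CC[C@@H](C(=O)NC(c3ccccc3)c3ccccc3)N2C(=O)[C@H]1NC(=O)[C@H](CC)NC`. It differs from compound 1 only at the saturated chain carbon bound to a saturated ring carbon: (ethylamino)methyl in place of amino on a saturated chain carbon bound to a saturated ring carbon. Among the measured compounds shown here, no measured pair shares a change of this kind, so there is no step to lean on. With the two measured numbers close to each other, the change in compound 3 is expected to leave the number in this assay roughly where compound 1 stands; the expected step is a 1.1-fold higher number from compound 1 to compound 3 (0.03 log units; within the scatter), nothing beyond the scatter in either direction. Compound 3 is therefore estimated at 55000 nM, with a range of 20000 nM to 150000 nM.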

Compound 3, half-maximal inhibitory concentration: 76400 nM
Beside the measured number, compound 3's estimate is 1.4-fold (0.14 log units) below it; measured number inside the range.
By their numbers in this assay, from the lowest: compounds 1, 3 and 2 (each within the scatter of the next).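

In this assay, among the compounds shown here, (ethylamino)methyl in place of amino on a saturated chain carbon bound to a saturated ring carbon gives a 1.5-fold higher number from compound 1 to compound 3 (0.17 log units; within the scatter) and provides the first comparison between compounds that differ in one place. This position therefore accepts the entering group, with its 4 heavy atoms against 1 for the group that leaves, without a step beyond the scatter, while the counts of hydrogen-bond donors and acceptors in the two groups stay the same. No measured evidence here accounts for this result.

This single step cannot separate the extension from aminomethyl to 2-(ethylamino)ethyl into the effect of the added chain length and that of the ethyl group on the amine nitrogen. It also leaves open whether a carboxylic acid, a piperidine or a much longer alkyl chain at this place would move the number in this assay beyond the scatter in either direction.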